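The source may report more compounds than this note shows. Statements on the series, on what has been measured and on what is new or still open speak of the compounds shown alone.

Compound 2 `Cc1c(/N=C/c2ccc(Cl)cc2)c(=O)n(-c2ccccc2)n1C` gives the highest of the two numbers in a functional assay on DLD-1 cells (Homo sapiens) for cytotoxicity, read by MTT assay, with a stated time of 72 h (on this read-out lower numbers stand for stronger inhibition and higher numbers for weaker inhibition), so far, at 631000000 nM. Its nearest neighbour, compound 1 `Cc1c(/N=C/c2cccc([N+](=O)[O-])c2)c(=O)n(-c2ccccc2)n1C`, gives 490000000 nM in this assay, a gap that sits within the scatter, so no order between the two can be read. Compound 3 `Cc1c(/N=C/c2cccc(Cl)c2)c(=O)n(-c2ccccc2)n1C` differs from compound 2 by 3-chlorophenyl in place of 4-chlorophenyl on a carbon with a double bond to nitrogen. Within the data shown here, no measured pair shows the effect of such a swap, so the step from compound 2 to compound 3 in this assay is expected to stay within the scatter, in either direction, as a 1.1-fold lower number from compound 2 to compound 3 (0.02 log units; within the scatter). Compound 3 is estimated at 600000000 nM in this assay, within 200000000 nM to 1800000000 nM.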

Compound 3, half-maximal inhibitory concentration: 724000000 nM
Compound 3: middle estimate off by 1.2-fold (0.08 log units), on the low side; the measured number falls inside the stated range.
By their numbers in this assay, from the lowest: compounds 1, 2 and 3 (each within the scatter of the next).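

Swapping 4-chlorophenyl for 3-chlorophenyl on the carbon with a double bond to nitrogen gives a 1.1-fold higher number from compound 2 to compound 3 (0.06 log units; within the scatter) in this assay and so shows no measurable dependence on where the chloro group sits. Chloro in place of nitro on an aromatic carbon gives a 1.5-fold higher number from compound 1 to compound 3 (0.17 log units; within the scatter) in this assay and likewise separates neither group from the other. Nothing available explains these small steps.

As far as these compounds go, whether an amine or a carboxylic acid in place of the chloro would move the number beyond the scatter remains open. Changes to the shared core also remain open.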